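The source may report more compounds than this note shows. Statements on the series, on what has been measured and on what is new or still open speak of the compounds shown alone.

In an assay on SHEP1 cells for displacement of a labelled ligand from Neuronal acetylcholine receptor; alpha4/beta2 (Homo sapiens), read by scintillation counting, with a stated time of 2 h (a higher number here means a weaker inhibitor, a lower number a stronger inhibitor), two compounds have been measured. Compound 1 `COC(=O)N1CC2CNCC2C1` gives 23 nM, and compound 2 `O=C(C1CC1)[C@H]1C[C@H]2CNC[C@H]2C1` gives 0.5 nM. Compound 2 therefore stands at the lowest number of the two, and its distance from compound 1 is wide enough to lie beyond the usual scatter of repeated measurements, so compound 2 is the stronger inhibitor of the pair.

Compound 3 `CNC(=O)[C@H]1C[C@H]2CNC[C@H]2C1` has not yet been measured. It differs from compound 2 in one place: methylamino in place of cyclopropyl on a carbonyl carbon. Among the measured compounds shown here, no measured pair in this set shows a change of exactly this kind, so there is no measured step to lean on. The carbonyl carbon and the shared core stay the same, and only the group attached to that carbon changes. Compound 3 is expected to remain a strong inhibitor, and the step of an 8.0-fold higher number from compound 2 to compound 3 (0.90 log units; beyond the scatter) is my estimate, pointing toward a weaker inhibitor by a modest margin. For compound 3 the expected value is 4 nM, with a range from 0.8 nM to 20 nM.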

Compound 3, inhibition constant: 180 nM
The estimate for compound 3 lay 45-fold (1.65 log units) below the measured number; the whole stated range lies below it.
By their numbers in this assay, from the lowest: compound 2; then compound 1; then compound 3.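

On the carbonyl carbon, the choice of group matters far more than its small size might suggest: in this assay, methylamino in place of cyclopropyl gives a 360-fold higher number from compound 2 to compound 3 (2.56 log units; beyond the scatter), a large step toward a weaker inhibitor. The swap is modest on paper, with one three-membered carbon ring leaving and a group with one hydrogen-bond donor entering, yet the shared core alone does not keep the number low. Nothing measured here accounts for the loss.

Because the change removes the ring and adds both a nitrogen and the amide hydrogen at once, the compounds shown cannot tell these features apart. An isopropyl group on the same carbonyl carbon would keep carbon only without the ring, while a dimethylamino group would keep the nitrogen without the amide hydrogen.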